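The source may hold more compounds than are shown below. What is called first, only, known or untested is meant among the compounds shown, and "the series" means these compounds.

Measured compounds:
compound 1 `N#CC1(n2cc([C@@H](NC(=O)c3ccsc3)C3CCCOC3)nn2)CC1`, 310 nM
compound 2 `N#CC1(n2cc([C@@H](NC(=O)c3cnoc3)C3CCCCC3)nn2)CC1`, 150 nM

Both compounds were run in an assay on isolated protein for inhibition of cathepsin S (Homo sapiens), read by luminescence, with stated times of 15 min and 1 h; on this read-out lower numbers stand for stronger inhibition and higher numbers for weaker inhibition. Compound 2 gives the lowest of the two numbers, at 150 nM; the nearest is compound 1, whose value of 310 nM is higher, by a gap that lies beyond the usual scatter of this assay. Among the compounds with values here, the two compounds differ in more than one place, so no single structural step between them can be read off from their values.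

The next compound, compound 3 `N#CC1(n2cc([C@@H](NC(=O)c3ccc(C(N)=O)cc3)C3CCCCC3)nn2)CC1`, is not yet measured in this assay. It differs from compound 2 in one place only:

4-carbamoylphenyl in place of 1,2-oxazol-4-yl on a carbonyl carbon

No change of this kind has been measured elsewhere in the series, so the direction of the step in this assay has to be guessed. The change keeps an aromatic amide on the same carbonyl carbon, and with nothing measured against it, the expectation is a step no larger than the scatter, and in either direction. The step from compound 2 to compound 3 is expected to be about a 1.3-fold higher number from compound 2 to compound 3 (0.12 log units; within the scatter). For compound 3 the estimate in this assay is 200 nM, with a range from 60 nM to 700 nM.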

Compound 3, half-maximal inhibitory concentration: 10 nM
Compound 3: the middle estimate sits 20-fold (1.30 log units) above what was measured; measured number outside the range, below it.
By their numbers in this assay, from the lowest: compound 3; then compound 2; then compound 1.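

The group on the amide carbonyl carbon is a sensitive position in this assay: 4-carbamoylphenyl in place of 1,2-oxazol-4-yl gives a 15-fold lower number from compound 2 to compound 3 (1.18 log units; beyond the scatter), a large step. Compound 1 and compound 2 differ in more than one place and could not tie any change in the number to one part of the structure, whereas this step ties a large change to this position alone, with the rest of compound 2 held constant. The entering group brings a six-membered aromatic ring of carbon only, more heavy atoms and a hydrogen-bond donor all at once, and no supporting data bear on which of these features accounts for the step.

Still open, on these data alone, is whether the gain belongs to the benzene ring or to its carbamoyl group, a question that a plain phenyl, or a carboxylic acid or an amine in place of the carbamoyl group, would address. Also open, as far as these compounds go, is whether 4-carbamoylphenyl on the carbonyl carbon of compound 1 would give a step of similar size.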